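The source may report more compounds than this note shows. Statements on the series, on what has been measured and on what is new or still open speak of the compounds shown alone.

Measured so far:
Compound 1 `CNC(=O)Nc1ccc(-c2nc(N3CC4CCC(C3)O4)c3sc(CN4CCN(S(C)(=O)=O)CC4)cc3n2)cc1`: in a functional assay on LNCaP cells (Homo sapiens) for cytotoxicity (on this read-out higher numbers stand for weaker inhibition and lower numbers for stronger inhibition), compound 1 gives 120 nM.
Compound 2 `O=C(Nc1ccc(-c2nc(N3CC4CCC(C3)O4)c3sccc3n2)cc1)Nc1cccnc1`: in this assay compound 2 gives 27 nM.
Compound 3 `O=C(Nc1ccc(-c2nc(N3CC4CCC(C3)O4)c3sccc3n2)cc1)NC1CC1`: in this assay compound 3 gives 40 nM.

Among these three numbers compound 3 stands second highest; its nearest neighbour is compound 2, and the gap between them, a 1.5-fold higher number from compound 2 to compound 3 (0.17 log units; within the scatter), lies within the scatter. Compound 1 sits furthest away, with a number beyond the scatter from that of compound 3, but compound 1 differs from compound 3 in more than one place, so only the two values themselves can be compared.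

Compound 4 `CNC(=O)Nc1ccc(-c2nc(N3CC4CCC(C3)O4)c3sccc3n2)cc1` has not been measured. It differs from compound 3 by methyl in place of cyclopropyl on an amide-type nitrogen. Going by the values given here, the one measured step at the same place, a 1.5-fold higher number from compound 2 to compound 3 (0.17 log units; within the scatter), was small and within the scatter, so the substituent on the amide-type nitrogen has so far made little difference in this assay. Compound 4 is therefore expected to give a number close to that of compound 3, with no step beyond the scatter, and the expected step is a 1.3-fold higher number from compound 3 to compound 4 (0.10 log units; within the scatter). Compound 4 is estimated at 50 nM, with a range from 20 nM to 150 nM.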

Compound 4, half-maximal inhibitory concentration: 85 nM
Beside the measured number, compound 4's estimate is 1.7-fold (0.23 log units) below it, within the range that was stated.
By their numbers in this assay, from the lowest: compounds 2 and 3 (each within the scatter of the next); then compounds 4 and 1 (each within the scatter of the next).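

Going by these compounds alone, the substituent on the amide-type nitrogen does register in this assay: methyl in place of cyclopropyl (a 2.1-fold higher number from compound 3 to compound 4 (0.33 log units; beyond the scatter)) and methyl in place of pyridin-3-yl (a 3.1-fold higher number from compound 2 to compound 4 (0.50 log units; beyond the scatter)) are both modest steps beyond the scatter, whereas the one step read earlier, between pyridin-3-yl and cyclopropyl, stayed within it. With methyl on that nitrogen, hydrogen in place of (4-(methylsulfonyl)piperazin-1-yl)methyl on an aromatic carbon (a 1.4-fold lower number from compound 1 to compound 4 (0.15 log units; within the scatter)) stays within the scatter, so that change has no readable effect in this pair. No measured data bear on why methyl differs from the two ring-bearing groups.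

Open, on these data alone, is whether the ring itself matters or only the number of atoms, which an ethyl or isopropyl group on the same nitrogen would help separate. Also open, as far as these compounds go, is how an amine or a carboxylic acid would read at the aromatic carbon.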